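The source may report more compounds than this note shows. Statements on the series, on what has been measured and on what is new or still open speak of the compounds shown alone.

Measured compounds:
- compound 1, `COc1ccc(Nc2nnc(-c3cc(-c4ccc(F)cc4F)ccc3O)o2)cc1`, gives 35.3% in a functional assay on the whole organism (strain BALB/c) for inhibition, with Mus musculus as the target, read by paw edema, with a stated time of 4 h, at a dose of 50 mg/kg by the oral route; on this read-out lower numbers stand for less inhibition and higher numbers for more inhibition at the one dose given (going by the name of the read-out)
- compound 2, `CCNc1nnc(-c2cc(-c3ccc(F)cc3F)ccc2O)o1`, gives 36.8% in this assay

Compound 2 holds the higher of the two numbers, but its margin over compound 1 is small: the step of a number 1.5 percentage points higher from compound 1 to compound 2 (within the scatter) lies within the scatter, so the two compounds cannot be ordered on these data.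

Compound 3, `Oc1ccc(-c2ccc(F)cc2F)cc1-c1nnc(Nc2ccccc2)o1`, has not yet been measured in this assay. It differs from compound 2 by phenyl in place of ethyl on a nitrogen on an aromatic ring.

Going by the values given here, the only measured step that bears on this change is a number 1.5 percentage points higher from compound 1 to compound 2 (within the scatter), in which a 4-methoxyphenyl group at the same nitrogen was exchanged for ethyl without moving the read-out beyond the scatter. A phenyl group at that nitrogen is therefore expected to leave the number close to that of compound 2, with no step beyond the scatter in either direction. For compound 3 the expected step is a number 0.8 percentage points lower from compound 2 to compound 3 (within the scatter). The estimate for compound 3 is 36%, with a range from 24% to 48%.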

Compound 3, a percentage reported as inhibition, in the whole organism at one dose (the size of the read-out at that dose, not a potency): 39.5%
Beside the measured number, compound 3's estimate is 3.5 percentage points below it, and the stated range covers the measured number.
By their numbers in this assay, from the lowest: compounds 1, 2 and 3 (each within the scatter of the next).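

Phenyl in place of ethyl on the nitrogen gives a number 2.7 percentage points higher from compound 2 to compound 3 (within the scatter) in this assay and hydrogen in place of methoxy on an aromatic carbon gives a number 4.2 percentage points higher from compound 1 to compound 3 (within the scatter) on the same read-out. The nitrogen has now carried a chain, a bare phenyl ring and a 4-methoxyphenyl ring without any step going beyond the scatter, so neither the ring in place of ethyl nor the methoxy on that ring separates these compounds. Nothing at hand accounts for this result.

Going by these compounds, whether a longer chain such as butyl, a free amino group at this nitrogen, or a carboxylic acid on the phenyl ring would move the number beyond the scatter stays open. Also open, on these data alone, is whether these three compounds would stay this close at another dose or at another time after dosing.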